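This account rests on a few compounds, and the source may have more. Where it says the series, first, only, none or still open, it means among the compounds named here.

Working notes on the series. In a functional assay on KB cells (Homo sapiens) for inhibition, read by sulforhodamine B assay (a lower number here means a stronger inhibitor of growth, a higher number a weaker inhibitor of growth), compound 1 `FC(F)(F)c1ccc(-c2ccc(-c3ccc(-c4nc5ccccc5[nH]4)cc3)cc2)cc1` gives 47200 nM, compound 2 `Oc1ccc(-c2ccc(-c3ccc(-c4nc5ccccc5[nH]4)cc3)cc2)cc1` gives 41000 nM and compound 3 `COc1ccc(-c2ccc(-c3ccc(-c4nc5ccccc5[nH]4)cc3)cc2)cc1` gives 47200 nM. Compound 2 thus stands within the scatter of both other compounds, and the numbers do not separate the three. Compound 4 `Cc1ccc2[nH]c(-c3ccc(-c4ccc(-c5ccc(O)cc5)cc4)cc3)nc2c1` differs from compound 2 by methyl in place of hydrogen on an aromatic carbon.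

The measured steps all concern a different site, and none replaces this hydrogen: a 1.2-fold lower number from compound 1 to compound 2 (0.06 log units; within the scatter), no change at the digits printed from compound 1 to compound 3 (within the scatter) and a 1.2-fold higher number from compound 2 to compound 3 (0.06 log units; within the scatter), each within the scatter. The last of these also adds a methyl, but on an oxygen rather than on an aromatic carbon. These steps therefore bear on the new change only indirectly, and no direct comparison exists for it. With that caveat, no step beyond the scatter is expected in this assay. The expected step is a 1.1-fold lower number from compound 2 to compound 4 (0.03 log units; within the scatter). For compound 4 the estimated value is 38000 nM, with an expected range of 17000 nM to 75000 nM.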

Compound 4, concentration for 50% growth inhibition: 21200 nM
Compound 4: middle estimate off by 1.8-fold (0.25 log units), on the high side, within the range that was stated.
By their numbers in this assay, from the lowest: compounds 4, 2, 1 and 3 (each within the scatter of the next, the first and the last beyond it).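

Among the compounds shown here, this is the first measured change on the six-membered aromatic ring of carbon only that is part of the fused system, and in this assay methyl in place of hydrogen there gives a 1.9-fold lower number from compound 2 to compound 4 (0.29 log units; within the scatter). The step lies within the scatter, so this carbon accepts a methyl without a change that the assay can separate, and the same holds for the methyl on oxygen, with a 1.2-fold higher number from compound 2 to compound 3 (0.06 log units; within the scatter). No measurement on hand bears on the reason for this result.

From the compounds shown here alone, it remains open whether an amine, a carboxylic acid or a longer chain on this carbon would give a step beyond the scatter. Going by these compounds, it is also open whether the methyl would give a similar step with methoxy or trifluoromethyl in place of the hydroxy group.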